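Anilino sulfonyl series: fluoro for amino on the aniline

A few compounds are considered here, and "the series" means these few. Any claim that something is new, unique, unknown or untested is made for them only; others in the source may bear on it.

Compound 3 `Cc1ccc(S(=O)(=O)c2nc3ccccc3nc2Nc2ccc(N)cc2)cc1` gives 5000 nM in a functional assay on PC-3 cells (Homo sapiens) for cytotoxicity, read by MTT assay, with a stated time of 72 h (on this read-out lower numbers stand for stronger inhibition and higher numbers for weaker inhibition), the highest of the three numbers in hand. Compound 1 `Cc1ccc(S(=O)(=O)c2nc3ccccc3nc2Nc2ccccc2)cc1` gives 1060 nM, and compound 2 `COc1cc(Nc2nc3ccccc3nc2S(=O)(=O)c2ccc(C)cc2)cc(OC)c1` gives 2940 nM. The change from compound 3 to compound 4 `Cc1ccc(S(=O)(=O)c2nc3ccccc3nc2Nc2ccc(F)cc2)cc1` is fluoro in place of amino on an aromatic carbon, so the (4-aminophenyl)amino becomes a (4-fluorophenyl)amino.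

The step that bears most directly on this is the reverse of the one that introduced the amino group: a 4.7-fold higher number from compound 1 to compound 3 (0.67 log units; beyond the scatter). The other two steps concern the dimethoxy pattern, a 2.8-fold higher number from compound 1 to compound 2 (0.44 log units; beyond the scatter) and a 1.7-fold higher number from compound 2 to compound 3 (0.23 log units; within the scatter), and say little about the amino position. Removing the amino group is therefore expected to move the number back toward that of compound 1, though fluoro is not hydrogen and the return is expected to be incomplete. For compound 4 the estimate in this assay is 1600 nM, with a range of 600 nM to 4000 nM, meaning an expected step of a 3.1-fold lower number from compound 3 to compound 4 (0.49 log units; beyond the scatter), a lower number beyond the scatter.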

Compound 4, half-maximal inhibitory concentration: 13100 nM
Compound 4: middle estimate off by 8.2-fold (0.91 log units), on the low side; measured number above the stated range.
By their numbers in this assay, from the lowest: compound 1; then compounds 2 and 3 (each within the scatter of the next); then compound 4.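

In this assay, the carbon para to a large group does not behave as if removing the amino group restores the number of compound 1: fluoro in place of amino goes the other way (a 2.6-fold higher number from compound 3 to compound 4 (0.42 log units; beyond the scatter)). Going by these compounds alone, measured against hydrogen at this place, both groups go with a higher number, but fluoro (a 12-fold higher number from compound 1 to compound 4 (1.09 log units; beyond the scatter)), the only large step here, exceeds amino (a 4.7-fold higher number from compound 1 to compound 3 (0.67 log units; beyond the scatter)). The 4-fluorophenyl also stands above the 3,5-dimethoxyphenyl on the nitrogen (a 4.5-fold higher number from compound 2 to compound 4 (0.65 log units; beyond the scatter)), which leaves the plain phenyl of compound 1 with the lowest number of the four.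

No measured data bearing on the reason for this order are available. From the compounds shown here alone, whether any group at this carbon raises the number stays open: methoxy, chloro or a carboxylic acid there, with the rest of compound 1 kept, would test it.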